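The source may hold more compounds than are shown below. What is called first, only, known or untested is meant among the compounds shown, and "the series" means these compounds.

Compound 1, with the structure `Cc1ccc(-c2ccc(NCc3ccccc3O)cc2)cc1`, and compound 2, with the structure `COc1ccc(-c2ccc(NCc3ccccc3O)cc2)cc1`, share one core and differ by a single change, (methoxy in place of methyl on an aromatic carbon). In a functional assay on Jurkat cells (Homo sapiens) for activation, with a stated time of 24 h (on this read-out lower numbers stand for an effect already at smaller amounts and higher numbers for an effect only at larger amounts of compound), compound 1 gives 3790 nM, while compound 2 gives 580 nM, so the change made a step of a 6.5-fold lower number from compound 1 to compound 2 (0.82 log units; beyond the scatter). Compound 3, with the structure `Cc1ccc(-c2ccc(NCc3ccccc3O)cn2)cc1`, carries the methyl on a different core; the difference between the two cores is not broken down here. In this assay compound 3 is reported as "not active" (no number reported), without a number. Compound 4, with the structure `COc1ccc(-c2ccc(NCc3ccccc3O)cn2)cc1`, is compound 3 with the same change, (methoxy in place of methyl on an aromatic carbon), the place being described in the same words in both cases. Compound 4 has not yet been measured. Going by the values given here, since the only step available is a 6.5-fold lower number from compound 1 to compound 2 (0.82 log units; beyond the scatter) on the other core, and compound 3 gave no number, compound 4 is expected to land around 8000 nM, between 1500 nM and 40000 nM, with a real chance that again no number is obtained.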

Compound 4, half-maximal effective concentration: 4760 nM
Compound 4: the middle estimate sits 1.7-fold (0.23 log units) above what was measured, and the stated range covers the measured number.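

Going by these compounds alone, compound 3 is reported as not active, without a number, so no step from compound 3 to compound 4 can be read. On these data alone, how far methoxy in place of methyl shifts the read-out on this core stays open. No further data here bear on the reason for this result.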